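Tracing an indanol amine into a serotonin receptor series

The source may hold more compounds than are shown below. What is called first, only, known or untested is meant among the compounds shown, and "the series" means these compounds.

Of the compounds shown here, three sharing one core have been measured in an assay on CHO cells for agonist activity at 5-hydroxytryptamine receptor 1D (Homo sapiens), read by GTPgammaS binding; a lower number here means that less compound is needed, a higher number that more compound is needed for the effect. Compound 1, `c1ccc(CNC2CCN(CCCc3c[nH]c4ccc(-n5cnnc5)cc34)CC2)cc1`, gives 7.6 nM. Compound 2, `CC(C)=CCN(C)C1CCN(CCCc2c[nH]c3ccc(-n4cnnc4)cc23)CC1`, gives 1.8 nM. Compound 3, `CN(Cc1ccsc1)C1CCN(CCCc2c[nH]c3ccc(-n4cnnc4)cc23)CC1`, gives 4.2 nM. Among these numbers compound 3 stands second highest: its nearest neighbour is compound 1, a 1.8-fold lower number from compound 1 to compound 3 (0.26 log units; within the scatter), while the furthest is compound 2, a 2.3-fold higher number from compound 2 to compound 3 (0.37 log units; beyond the scatter). The third step, a 4.2-fold lower number from compound 1 to compound 2 (0.63 log units; beyond the scatter), is the largest the set offers.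

Compound 4, `O[C@@H]1Cc2ccccc2[C@H]1NC1CCN(CCCc2c[nH]c3ccc(-n4cnnc4)cc23)CC1`, has not yet been measured. It differs from compound 3 at the same saturated ring carbon where all three measured compounds vary: (2-hydroxy-2,3-dihydro-1H-inden-1-yl)amino in place of methyl((thiophen-3-yl)methyl)amino on a saturated ring carbon. Going by the values given here, the measured steps at this position are modest at most, and the closest precedent, a swap of one amine substituent for another between compound 1 and compound 3, stayed within the scatter. Among the compounds with values here, nothing among the measured compounds speaks to a hydroxyl-bearing bicyclic amine, so the step is expected to be small, with a slight lean toward a higher number, a 1.9-fold higher number from compound 3 to compound 4 (0.28 log units; within the scatter). Compound 4 is therefore estimated at 8 nM in this assay, with a range from 2.5 nM to 30 nM.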

Compound 4, half-maximal effective concentration: 13 nM
For compound 4 the middle estimate is 1.6-fold (0.21 log units) below the measured one, within the range that was stated.
By their numbers in this assay, from the lowest: compound 2; then compounds 3, 1 and 4 (each within the scatter of the next, the first and the last beyond it).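

At this saturated ring carbon, the (2-hydroxy-2,3-dihydro-1H-inden-1-yl)amino group gives the widest spread yet seen in this assay: the step to it from the methyl(3-methylbut-2-en-1-yl)amino group is the largest in the set (a 7.2-fold higher number from compound 2 to compound 4 (0.86 log units; beyond the scatter)). Replacing the methyl((thiophen-3-yl)methyl)amino group also moves the number upward beyond the scatter (a 3.1-fold higher number from compound 3 to compound 4 (0.49 log units; beyond the scatter)), so this position does respond to the choice of amine substituent by more than the earlier thiophene comparison with compound 1 suggested. Against the benzylamino group, however, the change on the amine nitrogen stays within the scatter (a 1.7-fold higher number from compound 1 to compound 4 (0.23 log units; within the scatter)), so the larger bicyclic group with its hydroxyl is not separated from a plain benzyl here.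

The compounds offer no explanation for these differences. Still open, from the compounds shown here alone, is what each feature of the new group contributes, which a 2,3-dihydro-1H-inden-1-yl group without the hydroxyl, the opposite arrangement at the two stereocentres, or a methyl on the amine nitrogen of compound 4 could each address.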